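The source may report more compounds than this note shows. Statements on the series, on what has been measured and on what is new or still open speak of the compounds shown alone.

Compound 1 `CC1=C/C(=C\C(C)C)C(=O)C(C)(O)C12CC2` gives the lowest number of the three measured in a functional assay on SW480 cells (Homo sapiens) for antiproliferative activity; a higher number here means a weaker inhibitor, a lower number a stronger inhibitor; compound 1 stands at 30 nM. Compound 2 `C/C=C1\C=C(C)C2(CC2)C(C)(O)C1=O` gives 120 nM, and compound 3 `CC1=C/C(=C\c2ccccc2)C(=O)C(C)(O)C12CC2` gives 2500 nM. The steps are a 4.0-fold higher number from compound 1 to compound 2 (0.60 log units; beyond the scatter) and an 83-fold higher number from compound 1 to compound 3 (1.92 log units; beyond the scatter), with a 21-fold higher number from compound 2 to compound 3 (1.32 log units; beyond the scatter) between the two. Compound 4 `CC1=C/C(=C\Cl)C(=O)C(C)(O)C12CC2` differs from compound 1 by chloro in place of isopropyl on a double-bonded chain carbon bound to a double-bonded ring carbon. Both measured replacements at this place raised the number in this assay; chloro enters with one heavy atom, fewer than methyl, so the change is expected to resemble the modest step to compound 2 rather than the large step to compound 3, though no group of this kind has been tried here. Compound 4 is therefore expected at about 150 nM, range 40 nM to 600 nM, an estimated 5.0-fold higher number from compound 1 to compound 4 (0.70 log units; beyond the scatter).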

Compound 4, half-maximal inhibitory concentration: 30 nM
Compound 4: middle estimate off by 5.0-fold (0.70 log units), on the high side, and the stated range ends above it.
By their numbers in this assay, from the lowest: compounds 1 and 4 (each within the scatter of the next); then compound 2; then compound 3.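

In this assay, among these compounds, chloro is the first replacement of isopropyl at this place that stays within the scatter: no change at the digits printed from compound 1 to compound 4 (within the scatter). Heavy-atom count alone therefore does not order the series, since isopropyl with 3 heavy atoms and chloro with 1 heavy atom are not separated, whereas methyl and phenyl are, with a 4.0-fold lower number from compound 2 to compound 4 (0.60 log units; beyond the scatter) and an 83-fold lower number from compound 3 to compound 4 (1.92 log units; beyond the scatter). No supporting data bear on why these groups fall as they do.

Open, going by these compounds, is whether bromo, an amine or a longer chain at this place would stay level with compound 1.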